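Removing a Chloro Group from an Inactive Series

The source may hold more compounds than are shown below. What is called first, only, known or untested is meant among the compounds shown, and "the series" means these compounds.

Compound 1 `CC1=CSC(O)(c2ccc(C)cc2)c2noc(=O)n21`: in a functional assay on A2780 cells (Homo sapiens) for antiproliferative activity, read by MTT assay, with a stated time of 3 days (on this read-out higher numbers stand for weaker inhibition and lower numbers for stronger inhibition), compound 1 gives > 100000 nM, which is a limit of the assay and not a number.
Compound 2 `O=c1onc2n1C=CSC2(O)c1ccc(Cl)cc1`: in this assay compound 2 gives > 100000 nM, again a limit rather than a number.
Compound 3 `CCCCOC1(c2ccc(Cl)cc2)SC=C(C)n2c1noc2=O`: in this assay compound 3 gives 89000 nM.

Compound 2 therefore stands on the limit of this assay; nothing about its true potency is known beyond that. Among the measured compounds shown here, the same is true of compound 1, and the one compound that yields a number, compound 3, sits close to that limit. For the measured compounds named here, the dominant feature of the data is the limit of > 100000 nM in this assay, at which 2 of the 3 values shown sit, so the set gives no measured step from which a direction could be read.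

Compound 4 `O=c1onc2n1C=CSC2(O)c1ccccc1` arises from compound 2 by a single change: hydrogen in place of chloro on an aromatic carbon. Going by the values given here, with no step between measured compounds, no movement beyond the scatter is expected in this assay, and the result is expected to be a limit once more. Compound 4 is estimated at 150000 nM, with a range from 50000 nM to 500000 nM. The expected step is therefore a step that the limit leaves unreadable from compound 2 to compound 4, within the scatter.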

Compound 4, half-maximal inhibitory concentration: > 100000 nM
Compound 4: no number, only a limit; the forecaster's own chance of this, stated with the estimate: 80%; the middle value is on the limit's open side.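

Compound 4, like compound 2, gives only a limit of the assay and not a number, so no step can be read between them: the limit of > 100000 nM in this assay, at which 3 of the 4 values shown sit.

The compounds shown leave open how far the true potency of compound 2 and compound 4 lies from that limit, and whether exchanging chloro for hydrogen changes it at all.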